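The compounds below may be only part of what the source reports. "The series", "measured", "known", "first", "only" and "open" are said of these compounds alone.

In a functional assay on cells (Splenocyte, Mus musculus, strain BALB/c) for inhibition, read by scintillation counting and thymidine incorporation, with a stated time of 72 h (a higher number here means a weaker inhibitor, a lower number a stronger inhibitor), compound 1 `CC(/C=N/Nc1ccc([N+](=O)[O-])cc1)=N\NC(=O)c1ccc(C(C)(C)C)cc1` gives only a limit, > 12000 nM. Compound 2 `CC(/C=N/Nc1ccc([N+](=O)[O-])cc1)=N\NC(=O)c1ccccc1Oc1ccccc1` likewise gives only a limit in this assay, > 12000 nM. Compound 3 `CC(/C=N/N(C)c1ccc([N+](=O)[O-])cc1)=N\NC(=O)c1ccc(N)cc1` also stands at a limit in this assay, > 12000 nM. Within the data shown here, compound 1 thus has no number of its own: it sits where every value shown sits, at the limit of > 12000 nM in this assay, at which 3 of the 3 values shown sit, and no compound here can be called stronger or weaker than another.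

Compound 4 `COc1ccc(C(=O)N/N=C(C)/C=N/Nc2ccc([N+](=O)[O-])cc2)cc1` differs from compound 1 in one place: methoxy in place of tert-butyl on an aromatic carbon. Among the measured compounds shown here, no pair of measured compounds differs in just this way, so there is no measured step to lean on. Since compound 1 gives > 12000 nM only as a limit, compound 4 is expected to stay at or near that limit, with no step beyond the scatter, and the expected step is a step that the limit leaves unreadable from compound 1 to compound 4. Compound 4 is therefore estimated at 15000 nM, within a range from 5000 nM to 50000 nM, and most likely it will again be reported as a limit rather than a number.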

Compound 4, half-maximal inhibitory concentration: > 12000 nM
Compound 4 was reported as a limit; the forecaster's own chance of this, stated with the estimate: 80%; the middle value does not contradict the limit.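

Compound 1 and compound 4 are both reported only as limits, so no step can be read between them for methoxy in place of tert-butyl: the limit of > 12000 nM in this assay, at which 4 of the 4 values shown sit.

The compounds shown leave open which structural change, if any, would give a measurable value in this assay.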